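The compounds below may be only part of what the source reports. "The series", "measured", "known", "first", "only" and "open" are said of these compounds alone.

Compound 3, `CN1CCCN(CCn2ccc3ccc(N)cc32)CC1`, gives the lowest number of the three measured compounds in an assay on HEK293 cells for binding affinity to 5-hydroxytryptamine receptor 7 (Homo sapiens), read by radioligand binding, tested at 1 uM (a lower number here means less inhibition, a higher number more inhibition at the concentration tested (going by the name of the read-out)), where compound 3 gives 0%. The other two measured compounds carry a bromine on the shared core in place of the amino group and a different amine on the chain. In this assay compound 1, `Brc1ccc2ccn(CCN3CCNCC3)c2c1`, gives 61%, and compound 2, `Brc1ccc2ccn(CCN3CCC4CCCCN4CC3)c2c1`, gives 71%. Both stand far above compound 3, beyond the scatter, though each differs from compound 3 in two places, so those gaps cannot be traced to one change alone.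

Compound 4, `C=Cc1ccc2ccn(CCN3CCCN(C)CC3)c2c1`, keeps the chain and amine of compound 3 and alters only the aromatic substituent: vinyl in place of amino on an aromatic carbon. Among the compounds with values here, no measured pair isolates this change. The reading of compound 3 sits at the floor, so the step from compound 3 to compound 4 in this assay is expected to be upward, a number 40 percentage points higher from compound 3 to compound 4 (beyond the scatter), since compounds 1 and 2 show that a non-amino group at that position can coexist with clear inhibition. Compound 4 is estimated at 40%, with a range from 5% to 75%.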

Compound 4, a percentage reported as inhibition, at one concentration (the size of the read-out at that concentration, not a potency): 79%
The estimate for compound 4 lay 39 percentage points below the measured number, outside the stated range (above it).
By their numbers in this assay, from the lowest: compound 3; then compounds 1, 2 and 4 (each within the scatter of the next, the first and the last beyond it).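

With the chain and amine held fixed, vinyl in place of amino on an aromatic carbon is the only difference, and in this assay this single change gives a number 79 percentage points higher from compound 3 to compound 4 (beyond the scatter). The gap that compounds 1 and 2 showed against compound 3 could not be traced to one place, but this pair shows that the group at this position alone can move the reading by a large amount. Nothing here shows why the number moves, and no measurement bears on the cause.

On these data alone, compounds 1 and 2 carry other amines, so how bromine would compare with vinyl on the amine of compound 4 stays open. Also open, as far as these compounds go, is how a saturated ethyl group, a methoxy group or a nitrile at this position would read.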